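A few compounds are considered here, and "the series" means these few. Any claim that something is new, unique, unknown or untested is made for them only; others in the source may bear on it.

Compound 1 `Cc1ccccc1N/C(=N\C#N)N1CCN(C(=O)Cc2ccoc2)C(c2ccccc2)C1`: 250 nM
Compound 2 `Cc1ccccc1N/C(=N\C#N)N1CCN(C(=O)Cc2ccsc2)C(c2ccccc2)C1`: 270 nM
Compound 3 `Cc1ccccc1N/C(=N\C#N)N1CCN(C(=O)Cc2cccs2)C(c2ccccc2)C1`: 150 nM

These three compounds share one core and differ only in the five-membered ring that sits on a saturated chain carbon bound to a carbonyl carbon. In a functional assay for antagonist activity at P2X purinoceptor 7 (Rattus norvegicus), read by FLIPR and calcium flux (on this read-out higher numbers stand for weaker inhibition and lower numbers for stronger inhibition), compound 1 gives 250 nM, compound 2 gives 270 nM and compound 3 gives 150 nM. The steps among them are all small: a 1.1-fold higher number from compound 1 to compound 2 (0.03 log units; within the scatter), a 1.7-fold lower number from compound 1 to compound 3 (0.22 log units; within the scatter) and a 1.8-fold lower number from compound 2 to compound 3 (0.26 log units; within the scatter). Compound 1 therefore cannot be told apart from either of the others on this assay, and the three numbers are best read as one level.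

Compound 4 `Cc1ccccc1N/C(=N\C#N)N1CCN(C(=O)Cc2c[nH]cn2)C(c2ccccc2)C1` has not been measured. It differs from compound 1 in 1H-imidazol-4-yl in place of furan-3-yl on a saturated chain carbon bound to a carbonyl carbon. The ring that enters brings a hydrogen-bond donor, which none of the three rings tried so far carries. Within the data shown here, the measured steps show only that exchanging one five-membered ring with a single hetero atom for another leaves the number unchanged within the scatter; they say nothing about a ring with two hetero atoms and a donor, so the expectation is held loosely. Compound 4 is expected to give 500 nM, within 150 nM to 2000 nM. That estimate means a step of a 2.0-fold higher number from compound 1 to compound 4 (0.30 log units; within the scatter), a somewhat higher number, with a fair chance that the step in fact stays within the scatter.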

Compound 4, half-maximal inhibitory concentration: 14000 nM
The estimate for compound 4 lay 28-fold (1.45 log units) below the measured number; measured number above the stated range.
By their numbers in this assay, from the lowest: compounds 3, 1 and 2 (each within the scatter of the next); then compound 4.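

In this assay, among these compounds, the place on a saturated chain carbon bound to a carbonyl carbon had so far looked undemanding, yet 1H-imidazol-4-yl in place of furan-3-yl gives a 56-fold higher number from compound 1 to compound 4 (1.75 log units; beyond the scatter) and the same ring gives a 52-fold higher number from compound 2 to compound 4 (1.71 log units; beyond the scatter) as well as a 93-fold higher number from compound 3 to compound 4 (1.97 log units; beyond the scatter) when it replaces the two thiophene rings. This position therefore does not accept every five-membered aromatic ring: the rings compared here all have 5 heavy atoms, so a ring of the same size can still move the number far beyond the scatter. The entering ring differs from the furan-3-yl ring in its second hetero atom, in having nitrogen in place of oxygen and in its hydrogen-bond donor, but nothing available here separates these features or accounts for the change.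

The compounds shown leave open whether an oxazol-4-yl or a 1-methylimidazol-4-yl ring would stay level with the furan and thiophene compounds or move towards compound 4. They also leave open how a plain phenyl ring or an amine on a longer chain would behave at this place.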